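Swapping a Nitrile for a Methoxy on the Sulfonyl Aryl

The compounds below may be only part of what the source reports. "The series", "measured", "known", "first", "only" and "open" are said of these compounds alone.

Of the compounds shown here, three sharing one core have been tested in an assay on isolated protein for displacement of a labelled ligand from metabotropic glutamate receptor 5 (Homo sapiens), with a stated time of 60 min, tested at 1 uM; on this read-out lower numbers stand for less inhibition and higher numbers for more inhibition at the one concentration tested (going by the name of the read-out). Compound 1 `COc1ccc2ncc(S(=O)(=O)c3ccc(C)c(Cl)c3)c(N3CCC(C)CC3)c2c1` gives 85% there. Compound 2 `COc1ccc2ncc(S(=O)(=O)c3ccc(Cl)c(Cl)c3)c(N3CCC(C)CC3)c2c1` gives 87% in this assay. Compound 3 `COc1ccc2ncc(S(=O)(=O)c3cccc(C#N)c3)c(N3CCC(C)CC3)c2c1` gives 90% in this assay. Compound 3 sits at the top of these three numbers, yet the moves a number 5 percentage points higher from compound 1 to compound 3 (within the scatter) and a number 3 percentage points higher from compound 2 to compound 3 (within the scatter) are both within the scatter, as is a number 2 percentage points higher from compound 1 to compound 2 (within the scatter), so the three cannot really be told apart.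

Compound 4 `COc1cccc(S(=O)(=O)c2cnc3ccc(OC)cc3c2N2CCC(C)CC2)c1` has not been measured yet. It differs from compound 3 in one place: methoxy in place of cyano on an aromatic carbon. Among the compounds with values here, both earlier changes to the group on the sulfonyl sulfur left the read-out essentially unmoved, and no measured pair tests methoxy against cyano directly. The expectation is therefore a step of a number 5 percentage points lower from compound 3 to compound 4 (within the scatter) in this assay, that is, none beyond the scatter. Compound 4 is estimated at 85%, within a range from 68% to 95%.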

Compound 4, a percentage reported as inhibition, at one concentration (the size of the read-out at that concentration, not a potency): 0%
Compound 4: the middle estimate sits 85 percentage points above what was measured; measured number below the stated range.
By their numbers in this assay, from the lowest: compound 4; then compounds 1, 2 and 3 (each within the scatter of the next).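

The group on the sulfonyl sulfur is less forgiving than the first three compounds suggested: this assay shows a number 90 percentage points lower from compound 3 to compound 4 (beyond the scatter) when methoxy replaces cyano, although the two groups match in heavy-atom count and hydrogen-bond acceptor count. The nitrile itself is not required, as compound 1 and compound 2 lack it and stay within the scatter of compound 3, yet the 3-methoxyphenyl group stands apart from both, with a number 87 percentage points lower from compound 2 to compound 4 (beyond the scatter) and a number 85 percentage points lower from compound 1 to compound 4 (beyond the scatter) in the same read-out. Nothing available here explains this loss.

On these data alone, whether a fluoro, ethoxy or hydroxy group in the same place would keep the read-out remains open. So does whether methoxy would cause the same loss elsewhere on this ring, or alongside a chloro group.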